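A few compounds are considered here, and "the series" means these few. Any claim that something is new, unique, unknown or untested is made for them only; others in the source may bear on it.

Compound 2 `COc1ccc(C2=NN(C(=O)CO[N+](=O)[O-])C(c3ccco3)C2)cc1OC` stands lowest of the three numbers in a functional assay on the whole organism (strain albino) for inhibition, with Rattus norvegicus as the target, read by paw edema, with stated times of 30 min and 2 h, at a dose of 100 mg/kg by the oral route (on this read-out lower numbers stand for less inhibition and higher numbers for more inhibition at the one dose given (going by the name of the read-out)), giving 37%, though its gap to compound 1 `COc1ccc(C2=NN(C(=O)CBr)C(c3ccco3)C2)cc1OC`, which gives 46%, lies within the scatter; compound 3 `COc1ccc(C2=NN(C(=O)CO[N+](=O)[O-])C(c3c(Cl)cccc3Cl)C2)cc1OC` gives 49%. The step of a number 9 percentage points lower from compound 1 to compound 2 (within the scatter) exchanged the group on the saturated chain carbon bound to the carbonyl carbon, while a number 12 percentage points higher from compound 2 to compound 3 (beyond the scatter) altered the aryl group on the saturated ring carbon. Compound 4 `COc1ccc(C2=NN(C(=O)C(C)O[N+](=O)[O-])C(c3ccco3)C2)cc1OC` differs from compound 2 by methyl in place of hydrogen on a saturated chain carbon bound to a carbonyl carbon and an oxygen on an unsaturated carbon. Within the data shown here, no measured step adds a methyl at this place; the one change already seen at this chain carbon stayed within the scatter, and the modest gain arose elsewhere. Compound 4 is therefore expected to show a number 1 percentage points higher from compound 2 to compound 4 (within the scatter), nothing beyond the scatter. The estimated inhibition of compound 4 is 38%, within 26% to 50%.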

Compound 4, a percentage reported as inhibition, in the whole organism at one dose (the size of the read-out at that dose, not a potency): 39%
The estimate for compound 4 lay 1 percentage points below the measured number, and the stated range covers the measured number.
By their numbers in this assay, from the lowest: compounds 2, 4, 1 and 3 (each within the scatter of the next, the first and the last beyond it).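

In this assay, methyl in place of hydrogen on the saturated chain carbon gave a number 2 percentage points higher from compound 2 to compound 4 (within the scatter), so the read-out at this chain carbon has now stayed within the scatter for a second kind of change. The larger exchange of bromomethyl for 1-(nitrooxy)ethyl on the carbonyl carbon gave a number 7 percentage points lower from compound 1 to compound 4 (within the scatter), which also stays within the scatter. Nothing at hand gives a reason for these results. The compounds shown leave open whether an ethyl group at this chain carbon, or an amine in place of nitrooxy, would move the number beyond the scatter. They also leave open whether the methyl would behave the same way alongside the 2,6-dichlorophenyl group of compound 3.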